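The source may report more compounds than this note shows. Statements on the series, on what has been measured and on what is new or still open speak of the compounds shown alone.

Measured in a functional assay on MGC-803 cells (Homo sapiens) for inhibition, read by MTT assay, with a stated time of 72 h; a lower number here means a stronger inhibitor, a higher number a weaker inhibitor:
- compound 1 `Cc1cc(N2CC[C@@H](C)[C@@H](N(C)c3ncnc4[nH]ccc34)C2)n2nc(SCc3ccccc3Br)nc2n1`: 27000 nM
- compound 2 `Cc1cc(N2CC[C@@H](C)[C@@H](N(C)c3ncnc4[nH]ccc34)C2)n2nc(SCc3csc4ccc(Cl)cc34)nc2n1`: > 100000 nM (a limit)
- compound 3 `CCCCCc1c(C)nc2nc(SCc3ccc(Cl)cc3)nn2c1N1CC[C@@H](C)[C@@H](N(C)c2ncnc3[nH]ccc23)C1`: > 100000 nM (a limit)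

Compound 2 stands at the limit of > 100000 nM in this assay, at which 2 of the 3 values shown sit, so it has a limit and no number. Compound 4 `Cc1cc(N2CC[C@@H](C)[C@@H](N(C)c3ncnc4[nH]ccc34)C2)n2nc(SCc3ccc(F)c(Cl)c3)nc2n1` puts 3-chloro-4-fluorophenyl in place of 5-chloro-1-benzothiophen-3-yl on a saturated chain carbon bound to a sulfur. For the measured compounds named here, the one measured step bearing on this is an at least 3.7-fold higher number from compound 1 to compound 2 (0.56 log units; beyond the scatter), where 5-chloro-1-benzothiophen-3-yl replaced 2-bromophenyl. The present change runs the opposite way, so a modest fall in the number is expected in this assay. Compound 3 warns against relying on this: it also has a six-membered aromatic ring of carbon only on that chain, and its > 100000 nM is a limit. The expected size is an at least 2.2-fold lower number from compound 2 to compound 4 (0.34 log units; beyond the scatter). For compound 4 the estimate is 45000 nM, with an expected range of 15000 nM to 100000 nM.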

Compound 4, half-maximal inhibitory concentration: 52000 nM
Beside the measured number, compound 4's estimate is 1.2-fold (0.06 log units) below it; the measured number falls inside the stated range.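

In this assay, a phenyl group at this place, on a saturated chain carbon bound to a sulfur, again gives a measurable value, whereas 5-chloro-1-benzothiophen-3-yl gives only a limit: an at least 1.9-fold lower number from compound 2 to compound 4 (0.28 log units; that floor lies within the scatter). On these data alone, that step starts from a limit, so its true size remains unknown. Exchanging 2-bromophenyl for 3-chloro-4-fluorophenyl gives a 1.9-fold higher number from compound 1 to compound 4 (0.28 log units; within the scatter), so these two halogenated phenyl groups are not separated here.

Still open, as far as these compounds go, is how a phenyl bearing a carboxylic acid or a dimethylamino group would read at this place, and whether any group there brings the number well under those of compound 1 and compound 4.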